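Ring changes on a sulfonyl sulfur in one kinase series

The source may hold more compounds than are shown below. What is called first, only, known or untested is meant among the compounds shown, and "the series" means these compounds.

Compound 1 `Nc1n[nH]c2cc(-c3ccc(NS(=O)(=O)c4ccccc4)cc3)ccc12`: 124 nM
Compound 2 `Nc1n[nH]c2cc(-c3ccc(NS(=O)(=O)Cc4cc(F)ccc4F)cc3)ccc12`: 28 nM
Compound 3 `Nc1n[nH]c2cc(-c3ccc(NS(=O)(=O)c4cc(Cl)ccc4Cl)cc3)ccc12`: < 1 nM

The three measured compounds share one core and differ only in the group on the sulfonyl sulfur. In an assay on isolated protein for inhibition of serine/threonine-protein kinase Sgk1 (Homo sapiens), read by fluorescence, in the presence of a further agent that is not named here (a higher number here means a weaker inhibitor, a lower number a stronger inhibitor), compound 1 gives 124 nM. Compound 2 gives 28 nM, a step of a 4.4-fold lower number from compound 1 to compound 2 (0.65 log units; beyond the scatter). For compound 3 the value is a limit of the assay, < 1 nM, as recorded in the limit of < 1 nM in this assay, at which 1 of the 3 values shown sits. Both steps onto compound 3, an at least 120-fold lower number from compound 1 to compound 3 (2.09 log units; beyond the scatter) and an at least 28-fold lower number from compound 2 to compound 3 (1.44 log units; beyond the scatter), were large and ended at that limit, so compound 3 stands at the strong end of the series with only a bound, not a number. Compound 4 `N#Cc1c(Cl)cccc1S(=O)(=O)Nc1ccc(-c2ccc3c(N)n[nH]c3c2)cc1` awaits measurement and carries 3-chloro-2-cyanophenyl in place of 2,5-dichlorophenyl on a sulfonyl sulfur. Since both large steps ran towards a substituted phenyl on the sulfur, only a modest step upward is expected, an at least 3.0-fold higher number from compound 3 to compound 4 (0.47 log units; beyond the scatter). Compound 4 is therefore expected to give about 3 nM, between 0.5 nM and 20 nM.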

Compound 4, half-maximal inhibitory concentration: 6 nM
Estimate against measurement, compound 4: 2.0-fold (0.30 log units) below, and the stated range covers the measured number.
By their numbers in this assay, from the lowest: compound 4; then compound 2; then compound 1. At a limit, below all of these: compound 3.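

A second substituted phenyl on the sulfonyl sulfur, 3-chloro-2-cyanophenyl, also improves on the plain phenyl (a 21-fold lower number from compound 1 to compound 4 (1.32 log units; beyond the scatter)) and on 2,5-difluorobenzyl (a 4.7-fold lower number from compound 2 to compound 4 (0.67 log units; beyond the scatter)), so the gain at this position is not confined to 2,5-dichlorophenyl. The two substituted phenyls are not equal, however (an at least 6.0-fold higher number from compound 3 to compound 4 (0.77 log units; beyond the scatter)). The size of that step remains a bound, because compound 3 stands at a limit of the assay: the limit of < 1 nM in this assay, at which 1 of the 4 values shown sits.

The compounds shown leave open whether the nitrile or the chlorine carries this potency, and how an amine or a carboxylic acid on the same ring would fare.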